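Amine variation on the shared core: estimate for compound 4

This account rests on a few compounds, and the source may have more. Where it says the series, first, only, none or still open, it means among the compounds named here.

Measured so far:
- Compound 1, `Cc1ccc(Cl)cc1Nc1nc(C(F)(F)F)ccc1CNC(=O)C(C)c1ccc(NS(C)(=O)=O)c(F)c1`: in a functional assay on CHO-K1 cells for antagonist activity at transient receptor potential cation channel subfamily V member 1 (Homo sapiens), read by FLIPR (on this read-out lower numbers stand for stronger inhibition and higher numbers for weaker inhibition), compound 1 gives 140 nM.
- Compound 2, `CCCCN(C)c1nc(C(F)(F)F)ccc1CNC(=O)C(C)c1ccc(NS(C)(=O)=O)c(F)c1`: compound 2 gives 21.3 nM.
- Compound 3, `CC(C(=O)NCc1ccc(C(F)(F)F)nc1N1CCC(c2ccccc2)CC1)c1ccc(NS(C)(=O)=O)c(F)c1`: compound 3 gives 25 nM.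

Compound 3 stands second highest of the three numbers. Its nearest neighbour is compound 2, with a 1.2-fold higher number from compound 2 to compound 3 (0.07 log units; within the scatter), a step within the scatter; the largest gap is to compound 1, with a 5.6-fold lower number from compound 1 to compound 3 (0.75 log units; beyond the scatter). The other step, a 6.6-fold lower number from compound 1 to compound 2 (0.82 log units; beyond the scatter), is of similar size.

Compound 4, `Cc1ccc(CC2CCN(c3nc(C(F)(F)F)ccc3CNC(=O)C(C)c3ccc(NS(C)(=O)=O)c(F)c3)CC2)cc1`, is the next candidate. It differs from compound 3 in one place: 4-methylbenzyl in place of phenyl on a saturated ring carbon. Going by the values given here, no measured step touches this saturated ring carbon, so no direct precedent exists. What the measured steps do show is that two quite different amines, in compound 2 and compound 3, land within the scatter of each other. On that basis a step of no more than the scatter is expected for no change at the digits printed from compound 3 to compound 4 (within the scatter). Compound 4 is therefore estimated at 25 nM, with a range from 8 nM to 80 nM.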

Compound 4, half-maximal inhibitory concentration: 17 nM
For compound 4 the middle estimate is 1.5-fold (0.17 log units) above the measured one, and the stated range covers the measured number.
By their numbers in this assay, from the lowest: compounds 4, 2 and 3 (each within the scatter of the next); then compound 1.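

In this assay, going by these compounds alone, 4-methylbenzyl in place of phenyl on a saturated ring carbon gives a 1.5-fold lower number from compound 3 to compound 4 (0.17 log units; within the scatter) and is the first measured change at this position, showing that the larger group, with 8 heavy atoms against 6, stays within the scatter. The earlier steps shown here exchanged the whole amine, whereas this one keeps the amine and alters only the group carried on its saturated ring carbon, with one six-membered aromatic ring of carbon present on both sides. Nothing in the available data gives a reason for this outcome.

The step combines the added benzylic carbon with the added methyl, so the two cannot be separated here. As far as these compounds go, how the position responds to a carboxylic acid, a primary amine or a longer alkyl chain in place of 4-methylbenzyl remains open.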